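Replacing the Carboxyfuran: Expectations for a Thiazole Analogue

A few compounds are considered here, and "the series" means these few. Any claim that something is new, unique, unknown or untested is made for them only; others in the source may bear on it.

Compound 1, `Cn1nc2c(=O)n(CC3(O)CCN(Cc4ccc(-c5ccsc5)cc4Cl)CC3)cnc2c1-c1ccc(CN)cc1`: 59.5 nM
Compound 2, `Cn1nc2c(=O)n(CC3(O)CCN(Cc4ccc(-c5ccc(C(=O)O)o5)cc4Cl)CC3)cnc2c1-c1ccc(CN)cc1`: 753 nM

In an assay on isolated protein for inhibition of ubiquitin carboxyl-terminal hydrolase 7 (Homo sapiens), with stated times of 30 min and 2 h (a lower number here means a stronger inhibitor, a higher number a weaker inhibitor), compound 2 gives the higher of the two numbers recorded so far. Within the data shown here, its only neighbour is compound 1, and the single measured step, a 13-fold higher number from compound 1 to compound 2 (1.10 log units; beyond the scatter), is the one that bears on the question at hand, since both compounds differ only at the five-membered ring attached to the chlorinated benzene.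

Compound 3, `Cn1nc2c(=O)n(CC3(O)CCN(Cc4ccc(-c5cncs5)cc4Cl)CC3)cnc2c1-c1ccc(CN)cc1`, has not yet been measured. It differs from compound 2 by 1,3-thiazol-5-yl in place of 5-carboxyfuran-2-yl on an aromatic carbon. The ring that enters, like the thiophen-3-yl of compound 1, carries no carboxylic acid and no net charge, so the measured step that connects compound 1 to compound 2 is expected to be largely undone. Compound 3 is therefore expected to show a 6.8-fold lower number from compound 2 to compound 3 (0.84 log units; beyond the scatter), a step beyond the scatter and in the opposite direction to the one observed, though with no assurance that the thiazole reaches exactly the level of compound 1. The estimate for compound 3 in this assay is 110 nM, with a range from 40 nM to 320 nM.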

Compound 3, half-maximal inhibitory concentration: 117 nM
Estimate against measurement, compound 3: 1.1-fold (0.03 log units) below; the measured number falls inside the stated range.
By their numbers in this assay, from the lowest: compounds 1 and 3 (each within the scatter of the next); then compound 2.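

In this assay, the high number of compound 2 now stands against a second ring at this position, on the aromatic carbon meta to a chloro group: with 1,3-thiazol-5-yl in place of 5-carboxyfuran-2-yl there is a 6.4-fold lower number from compound 2 to compound 3 (0.81 log units; beyond the scatter), so the gap no longer rests on thiophen-3-yl alone. Against the thiophene, the thiazole gives a 2.0-fold higher number from compound 1 to compound 3 (0.29 log units; within the scatter), and this step lies within the scatter, so in this assay the two rings cannot be told apart at this position. Nothing measured here explains either step, and no other data bear on them.

In compound 2, the furan ring and its carboxylic acid enter together, so the compounds shown do not separate what each contributes to the step. A plain furan-2-yl, a methyl ester in place of the carboxylic acid, or a carboxylic acid placed on the thiazole ring would speak to this, and an amine on the same ring would extend the comparison beyond uncharged rings and acids.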